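Swapping Chloro for Trifluoromethyl on an Aromatic Carbon

The source may hold more compounds than are shown below. What is called first, only, known or untested is meant among the compounds shown, and "the series" means these compounds.

Measured in a functional assay on the whole organism (strain Sprague-Dawley) for inhibition, with Rattus norvegicus as the target, with a stated time of 10 min; on this read-out higher numbers stand for an effect only at larger amounts of compound and lower numbers for an effect already at smaller amounts:
- Compound 1 `O=C(O)c1cnc(-c2ccc(C(F)(F)F)cc2)[nH]c1=O`: > 5 mg/kg, a limit
- Compound 2 `CCOC(=O)c1cnc(-c2ccc(Cl)cc2)[nH]c1=O`: > 30 mg/kg, a limit

Neither compound has yielded an actual number in this assay. Compound 2 stands only at > 30 mg/kg, which is a limit and not a measured dose. Compound 1 likewise stands only at a limit, > 5 mg/kg. Among the measured compounds shown here, these two limits set no order between compound 1 and compound 2, and they differ in more than one place, so they give no measured step to build on.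

The next compound is compound 3 `CCOC(=O)c1cnc(-c2ccc(C(F)(F)F)cc2)[nH]c1=O`. It differs from compound 2 in a single place, with trifluoromethyl in place of chloro on an aromatic carbon, para to a large group (trifluoromethyl in place of chloro on an aromatic carbon). Compound 1 carries the same trifluoromethyl, but it offers only a limit.

In this assay, no step beyond the usual scatter is expected in either direction, and another limit is the likeliest result. The expected change is a number no higher from compound 2 to compound 3 (the limit leaves the size open). Compound 3 is estimated at 30 mg/kg, with an expected range of 8 mg/kg to 60 mg/kg.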

Compound 3, dose for 50% inhibition: > 5 mg/kg
Compound 3: a limit, no number; the forecaster's own chance of this, stated with the estimate: 75%; the middle value does not contradict the limit.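

Compound 3 gives only a limit in this assay, and so do compound 1 and compound 2, so no step can be read from compound 2 to compound 3 or from compound 1 to compound 3. The compounds shown leave open the actual effective dose of each, and whether trifluoromethyl in place of chloro, or ethyl in place of hydrogen, changes it at all.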